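A few compounds are considered here, and "the series" means these few. Any claim that something is new, unique, unknown or untested is made for them only; others in the source may bear on it.

Compound 1 `Cc1cc(O)c(C2=NN(c3ccc(S(N)(=O)=O)cc3)C(c3ccccc3Cl)C2)cc1Cl` gives, in a functional assay on KM12 cells (Homo sapiens) for antiproliferative activity, with a stated time of 48 h (on this read-out higher numbers stand for weaker inhibition of growth and lower numbers for stronger inhibition of growth), a value of 1980 nM. Compound 2 `COc1ccc(C2CC(c3cc(Cl)c(C)cc3O)=NN2c2ccc(S(N)(=O)=O)cc2)cc1OC` shares its core and differs only in the aryl group on the saturated ring carbon; in this assay compound 2 gives 3070 nM. Going by the values given here, of the two numbers measured so far, compound 2 carries the higher one, its nearest neighbour being compound 1: the step of a 1.6-fold higher number from compound 1 to compound 2 (0.19 log units; within the scatter) stays within the scatter, so the two compounds cannot be told apart on this read-out.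

Compound 3 `COc1ccc(C2CC(c3cc(Cl)c(C)cc3O)=NN2c2ccc(S(N)(=O)=O)cc2)c(OC)c1OC` extends the change in the same direction. The difference from compound 2 is methoxy in place of hydrogen on an aromatic carbon, the new group entering on an aromatic carbon of a six-membered aromatic ring of carbon only, ortho to a large group, ortho to a methoxy group and meta to a methoxy group. Among the compounds with values here, no measured step adds a single methoxy group to an aryl ring; the only step available, from compound 1 to compound 2, swaps the whole aryl group and is itself within the scatter. A step no larger than the scatter is therefore expected, a 1.0-fold lower number from compound 2 to compound 3 (0.01 log units; within the scatter), in no settled direction. Compound 3 is expected to give about 3000 nM in this assay, within a range from 1400 nM to 6500 nM.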

Compound 3, concentration for 50% growth inhibition: 2280 nM
For compound 3 the middle estimate is 1.3-fold (0.12 log units) above the measured one; the measured number falls inside the stated range.
By their numbers in this assay, from the lowest: compounds 1, 3 and 2 (each within the scatter of the next).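

In this assay, methoxy in place of hydrogen on the aromatic carbon ortho to a large group gives a 1.3-fold lower number from compound 2 to compound 3 (0.13 log units; within the scatter), so a 2,3,4-trimethoxyphenyl group and a 3,4-dimethoxyphenyl group cannot be told apart on this read-out. Set against the 2-chlorophenyl group of compound 1, the 2,3,4-trimethoxyphenyl group gives a 1.2-fold higher number from compound 1 to compound 3 (0.06 log units; within the scatter), which again does not separate the two compounds; all three aryl groups shown on the saturated ring carbon therefore lie within the scatter of one another, and this aryl group has so far shown no step that the read-out can resolve. No supporting measurement accompanies these numbers to say anything further about this result.

On these data alone, whether an amine or a carboxylic acid on this aryl ring would give a step beyond the scatter remains open, as does the outcome of a longer chain, such as butoxy, in place of methoxy. The three compounds also share the rest of their structure, so they leave open how the read-out responds to a change anywhere outside this aryl group.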